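The source may report more compounds than this note shows. Statements on the series, on what has been measured and on what is new or still open speak of the compounds shown alone.

Of the compounds shown here, three of a shared core have been measured in a functional assay on the whole organism with Rattus norvegicus as the target, at a dose of 100 mg/kg; a higher number here means more inhibition at the dose given (going by the name of the read-out), a lower number less inhibition. Compound 1 `CC/N=C(/NC#N)NCCCCn1nc(-c2ccccc2)ccc1=O` gives 58.8% in this assay. Compound 2 `N/C(S)=N/CCCCn1nc(-c2ccccc2)ccc1=O` gives 72%, and compound 3 `C/N=C(\S)NCCCCCCn1nc(-c2ccccc2)ccc1=O` gives 22.2%. Among these three numbers compound 3 stands lowest: the step of a number 36.6 percentage points lower from compound 1 to compound 3 (beyond the scatter) is large, and the step of a number 49.8 percentage points lower from compound 2 to compound 3 (beyond the scatter) is larger still, while the step of a number 13.2 percentage points higher from compound 1 to compound 2 (beyond the scatter) is modest. The group found in compound 3 therefore goes with a lower number in this assay than either of the other two.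

Compound 4 `CC(C)C/N=C(\S)NCCCCn1nc(-c2ccccc2)ccc1=O` has not yet been measured in this assay. It differs from compound 3 in one place: a group of 8 heavy atoms (5 carbon, 2 nitrogen, 1 sulfur; no ring) in place of a group of 7 heavy atoms (4 carbon, 2 nitrogen, 1 sulfur; no ring), on a saturated chain carbon, four bonds along the chain from an aromatic nitrogen. Within the data shown here, no measured step changes exactly this group, so the two steps leading into compound 3 are the only guide. Both show that the group in compound 3 gives a much lower number than the groups in compound 1 and compound 2. Since compound 4 replaces that group, a rise beyond the scatter is expected, though its size is uncertain and the shared sulfur-bearing group leaves room for a smaller gain. The estimated step is a number 22.8 percentage points higher from compound 3 to compound 4 (beyond the scatter). Compound 4 is expected to give about 45% in this assay, in a range from 20% to 70%.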

Compound 4, a percentage reported as inhibition, in the whole organism at one dose (the size of the read-out at that dose, not a potency): 35.8%
Compound 4: middle estimate off by 9.2 percentage points, on the high side; measured number inside the range.
By their numbers in this assay, from the lowest: compound 3; then compound 4; then compound 1; then compound 2.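

At this saturated chain carbon, the group of 8 heavy atoms recovers only part of the ground in this assay, with a number 13.6 percentage points higher from compound 3 to compound 4 (beyond the scatter), while a number 36.2 percentage points lower from compound 2 to compound 4 (beyond the scatter) shows that it stays far short of the smaller group of 4 heavy atoms, which also carries sulfur. Sulfur alone therefore does not settle the number, since the three sulfur-bearing compounds now spread widely, with compound 2 at the top and compound 3 and compound 4 at the bottom. On the amine nitrogen, a number 23 percentage points lower from compound 1 to compound 4 (beyond the scatter) places the sulfur-free group of compound 1 above compound 4, although compound 2 goes against any simple advantage for the sulfur-free group by standing above compound 1.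

No measurement shown explains why these groups differ in this whole-organism read-out. The compounds shown also leave open how a carboxylic acid, a plain amine or a urea carbonyl in place of the sulfur-bearing group would compare in this assay, and whether a longer chain on the nitrogen would continue the spread seen here.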